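Moving a methyl group on a hydrazide antiproliferative series

A few compounds are considered here, and "the series" means these few. Any claim that something is new, unique, unknown or untested is made for them only; others in the source may bear on it.

Three compounds sharing one hydrazide-sulfonamide core were tested in a functional assay on MDA-MB-231 cells (Homo sapiens) for antiproliferative activity, read by MTT assay, with a stated time of 24 h; a higher number here means a weaker inhibitor, a lower number a stronger inhibitor. Compound 1 `Cc1ccccc1C(=O)NNC(=O)c1ccc(NS(=O)(=O)c2cnc(O)nc2O)cc1` gives 7040 nM in this assay. Compound 2 `Cc1ccc(C(=O)NNC(=O)c2ccc(NS(=O)(=O)c3cnc(O)nc3O)cc2)cc1` differs from compound 1 by a single change, (4-methylphenyl in place of 2-methylphenyl on a carbonyl carbon). In this assay compound 2 gives only a limit of the measurement, > 20000 nM, and not a number. That pair therefore defines a step: an at least 2.8-fold higher number from compound 1 to compound 2 (0.45 log units; beyond the scatter), read against (the limit of > 20000 nM in this assay, at which 1 of the 3 values shown sits). Compound 3 `Cc1ccccc1C(=O)NNC(=O)c1cccc(NS(=O)(=O)c2cnc(O)nc2O)c1` carries the same groups as compound 1, joined to the core in a different way; how the two cores differ is not broken down here. In this assay compound 3 gives 18100 nM, a higher number than compound 1, meaning weaker inhibition.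

Compound 4 `Cc1ccc(C(=O)NNC(=O)c2cccc(NS(=O)(=O)c3cnc(O)nc3O)c2)cc1` has not yet been measured. It stands to compound 3 exactly as compound 2 stands to compound 1: 4-methylphenyl in place of 2-methylphenyl on a carbonyl carbon. The place of the change is described in the same words in both pairs, so this is the same change made on the second core. Because that change gave an at least 2.8-fold higher number from compound 1 to compound 2 (0.45 log units; beyond the scatter), a step of at least similar size is expected from compound 3 to compound 4 in this assay, namely a 2.5-fold higher number from compound 3 to compound 4 (0.40 log units; beyond the scatter). Starting from the already weak compound 3, the expected result for compound 4 is 45000 nM, with a likely range from 20000 nM to 120000 nM, most probably reported only as a limit of the assay.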

Compound 4, half-maximal inhibitory concentration: > 20000 nM
Compound 4: no number, only a limit; the forecaster's own chance of this, stated with the estimate: 85%; the middle value lies beyond the limit too.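

In this assay compound 4 gives > 20000 nM, which is a limit of the assay and not a number. On the core of compound 3, putting 4-methylphenyl in place of 2-methylphenyl on a carbonyl carbon therefore yields only a floor, an at least 1.1-fold higher number from compound 3 to compound 4 (0.04 log units; that floor lies within the scatter), so the result agrees with a loss of activity like the one on the core of compound 1 but does not by itself establish a loss on this core. The two steps can be set side by side, but it cannot be said whether the change has the same size on both cores: the same change on two cores in this assay, an at least 2.8-fold higher number (0.45 log units; beyond the scatter) from compound 1 to compound 2 and an at least 1.1-fold higher number (0.04 log units; that floor lies within the scatter) from compound 3 to compound 4; the limit leaves it open whether they differ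

The true values of compound 2 and compound 4 also stay open, and so does any ranking of these two compounds: the limit of > 20000 nM in this assay, at which 2 of the 4 values shown sit. The compounds shown vary only the place of one methyl group on the phenyl ring, so it remains open how an unsubstituted phenyl, a methoxy group, a chlorine atom or a carboxylic acid on that ring would behave on either core.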